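The compounds below may be only part of what the source reports. "The series", "measured", "known", "first", "only" and "open" are said of these compounds alone.

Working notes on the series. In a functional assay on SK-MEL-2 cells (Homo sapiens) for inhibition, read by sulforhodamine B assay, with a stated time of 48 h (on this read-out lower numbers stand for stronger inhibition of growth and higher numbers for weaker inhibition of growth), compound 1 (`CN1CCCN(CCNc2nccc(-c3c(-c4cccc(O)c4)nc4sccn34)n2)S1(=O)=O`) gives 7360 nM and compound 2 (`O=S(=O)(NCCCNc1nccc(-c2c(-c3cccc(O)c3)nc3sccn23)n1)c1cccc(F)c1`) gives 6570 nM. Among the compounds with values here, compound 2 therefore stands level with compound 1, the only other measured compound, as the step of a 1.1-fold lower number from compound 1 to compound 2 (0.05 log units; within the scatter) lies within the scatter.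

Compound 3 (`O=S(=O)(NCCNc1nccc(-c2c(-c3cccc(O)c3)nc3sccn23)n1)c1ccc(F)cc1`) is not yet measured in this assay. Its change from compound 2 is ((4-fluorophenyl)sulfonyl)amino in place of (((3-fluorophenyl)sulfonyl)amino)methyl on a saturated chain carbon, two bonds along the chain from a nitrogen on an aromatic ring. In words, ((4-fluorophenyl)sulfonyl)amino replaces (((3-fluorophenyl)sulfonyl)amino)methyl on a saturated chain carbon, two bonds along the chain from a nitrogen on an aromatic ring.

Within the data shown here, no measured pair isolates this change. Among the measured compounds shown here, the one step that bears on it is a 1.1-fold lower number from compound 1 to compound 2 (0.05 log units; within the scatter), where a replacement at the same place left the number within the scatter. That single step is thin evidence, but it gives no ground for expecting a shift in either direction, so no step beyond the scatter is expected here. The expected step is a 1.0-fold lower number from compound 2 to compound 3 (0.00 log units; within the scatter).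

The estimate for compound 3 is 6500 nM, with an expected range of 3200 nM to 13000 nM.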

Compound 3, concentration for total growth inhibition: 20200 nM
Compound 3: middle estimate off by 3.1-fold (0.49 log units), on the low side; the measured number lies above the stated range.
By their numbers in this assay, from the lowest: compounds 2 and 1 (each within the scatter of the next); then compound 3.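

Unlike the earlier replacement at this place, the present change does move the number in this assay: a 3.1-fold higher number from compound 2 to compound 3 (0.49 log units; beyond the scatter) is a step that stands clear of the usual scatter, even though the group entering is only slightly smaller than the one leaving and keeps the same counts of donors and acceptors. The second new step points the same way, as a 2.7-fold higher number from compound 1 to compound 3 (0.44 log units; beyond the scatter) also lies beyond the scatter, so compound 3 stands apart from two compounds that carry very different groups at this place yet remain level with each other. The position therefore does respond to what is placed on it, although among these three compounds the size of the response does not follow the size or type of the group, and nothing on hand gives a reason for the rise in the number. 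

The step from compound 2 to compound 3 combines a shorter chain with a shift from 3-fluorophenyl to 4-fluorophenyl, and these compounds cannot separate the two changes. Also open, as far as these compounds go, is how the number would respond to an unsubstituted phenylsulfonyl group, a carboxylic acid or a longer chain at this place.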